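One ring swapped on the carbonyl carbon

The source may hold more compounds than are shown below. What is called first, only, known or untested is meant among the compounds shown, and "the series" means these compounds.

In a functional assay on St-4 cells (Homo sapiens) for inhibition, read by colorimetric assay and sulforhodamine B assay, with a stated time of 48 h (a higher number here means a weaker inhibitor of growth, a lower number a stronger inhibitor of growth), compound 1 (`CCCCCCCCCCCC[C@@H](O)[C@H]1CC[C@H]([C@H](O)CCCCCCCCCCNC(=O)c2ccoc2)O1`) gives 97700 nM and compound 2 (`CCCCCCCCCCCC[C@@H](O)[C@H]1CC[C@H]([C@H](O)CCCCCCCCCCNC(=O)c2ccsc2)O1`) gives 1700 nM, so compound 2 holds the lower, stronger of the two numbers. For the measured compounds named here, only one ring separates them: a 57-fold lower number from compound 1 to compound 2 (1.76 log units; beyond the scatter), with thiophen-3-yl in place of furan-3-yl on a carbonyl carbon. That large step, beyond the scatter, is the only measured one bearing on compound 3 (`CCCCCCCCCCCC[C@@H](O)[C@H]1CC[C@H]([C@H](O)CCCCCCCCCCNC(=O)c2ccnn2C)O1`), which changes the same place again: 1-methyl-1H-pyrazol-5-yl in place of thiophen-3-yl on a carbonyl carbon. Going by the values given here, it shows that this ring can move the number far, but no measured compound carries 1-methyl-1H-pyrazol-5-yl. Among the compounds with values here, compound 2, at 1700 nM, is the lower number so far, so an upward move seems likelier. The expected change is an 8.8-fold higher number from compound 2 to compound 3 (0.95 log units; beyond the scatter), a large step toward weaker inhibition. The estimated value for compound 3 is 15000 nM, within an expected range of 2500 nM to 90000 nM.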

Compound 3, concentration for 50% growth inhibition: 18200 nM
The estimate for compound 3 lay 1.2-fold (0.08 log units) below the measured number; low and high end bracket the measured number.
By their numbers in this assay, from the lowest: compound 2; then compound 3; then compound 1.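

In this assay, the 1-methyl-1H-pyrazol-5-yl ring gives a middle result: there is an 11-fold higher number from compound 2 to compound 3 (1.03 log units; beyond the scatter) and also a 5.4-fold lower number from compound 1 to compound 3 (0.73 log units; beyond the scatter) on the same carbonyl carbon. Both steps lie beyond the scatter, so the three five-membered aromatic rings give three distinct numbers at this position, with thiophen-3-yl still the lowest. No measurement here explains why these rings differ.

The compounds shown leave open whether a six-membered ring such as phenyl or pyridin-3-yl would match thiophen-3-yl, and whether removing the methyl from the pyrazole would move the number. They also leave open whether the same order of rings would hold with a shorter or longer chain between the amide nitrogen and the core.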